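From compound 2 to compound 3: one added chloro

A few compounds are considered here, and "the series" means these few. Any claim that something is new, unique, unknown or untested is made for them only; others in the source may bear on it.

Compound 1 `COc1ccc(Cn2cnc3c(-c4ccco4)ccnc32)cc1` and compound 2 `COc1ccc(Cn2cnc3c(-c4ccco4)nccc32)cc1` open the series. In an ADME assay on Vero cells (Chlorocebus sabaeus) for cytotoxicity (on this read-out lower numbers stand for stronger inhibition and higher numbers for weaker inhibition), compound 1 reads "not determined" (no result reported) so far. Compound 2 gives > 128000 nM as its reading, which is a limit of the assay and not a number. Compound 3 `COc1ccc(Cn2cnc3c(-c4ccco4)nc(Cl)cc32)cc1` differs from compound 2 by one change chloro in place of hydrogen on an aromatic carbon in which chloro takes the place of hydrogen on an aromatic carbon. Among the measured compounds shown here, with no measured step to lean on, a small shift towards stronger inhibition in this assay is expected, or none beyond the usual scatter. The estimated move is an at least 1.2-fold lower number from compound 2 to compound 3 (0.10 log units; that floor lies within the scatter) at most. For compound 3 the expected value is 100000 nM with an estimated range from 35000 nM to 128000 nM in all.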

Compound 3, half-maximal inhibitory concentration: > 128000 nM
Compound 3: only a limit was reported; the forecaster's own chance of this, stated with the estimate: 60%; at least 1.2-fold (0.10 log units) between middle value and limit.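

No step can be read from compound 2 to compound 3, because both readings in this assay are limits and not numbers: the limit of > 128000 nM in this assay, at which 2 of the 3 values shown sit. As far as these compounds go, whether chloro in place of hydrogen shifts this reading at all stays open.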